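The compounds below may be only part of what the source reports. "The series", "measured", "known", "first", "only" and "open" are said of these compounds alone.

Measured compounds in an ADME assay on MT4 cells (Homo sapiens) for cytotoxicity, read by MTT assay, with a stated time of 4 days; a higher number here means that more compound is tolerated, a lower number that less compound is tolerated:
- compound 1 `CCOC(=O)c1cnc(N2CCN(Cc3ccc(C#N)cc3)CC2)nc1Oc1c(C)cc(-c2ccc(C#N)cc2)cc1C`: > 125000 nM
- compound 2 `CCOC(=O)c1cnc(N2CCN(Cc3cccc(F)c3)CC2)nc1Oc1c(C)cc(-c2ccc(C#N)cc2)cc1C`: > 125000 nM

In this assay compound 1 gives > 125000 nM, which is a limit of the assay and not a number. In this assay compound 2 likewise gives > 125000 nM, again only a limit. The step that the two limits leave unreadable from compound 1 to compound 2 is therefore unreadable; both values sit at the limit of > 125000 nM in this assay, at which 2 of the 2 values shown sit. Compound 2 thus stands at the limit, with no number behind it.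

Compound 3 `CCOC(=O)c1cnc(N2CCN(Cc3ccc(C(=O)OC)cc3)CC2)nc1Oc1c(C)cc(-c2ccc(C#N)cc2)cc1C` differs from compound 2 by 4-(methoxycarbonyl)phenyl in place of 3-fluorophenyl on a saturated chain carbon bound to an amine nitrogen in a ring. Among the compounds with values here, the only measured step at the same place is the unreadable one from compound 1 to compound 2, which shows merely that two different groups there both left the value at the limit. No step beyond the scatter is therefore expected in this assay.

Compound 3 is estimated at 125000 nM, with a range from 60000 nM to 250000 nM. The step of a number no higher from compound 2 to compound 3 (the limit leaves the size open) is expected to be none beyond the scatter, most likely reported as a limit again.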

Compound 3, half-maximal cytotoxic concentration: > 125000 nM
Compound 3: a limit, no number (the forecaster's own chance of this, stated with the estimate: 85%); the middle value sits exactly at the limit.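

In this assay compound 3 gives > 125000 nM, a limit of the assay and not a number. No step among compound 1, compound 2 and compound 3 can be read: the limit of > 125000 nM in this assay, at which 3 of the 3 values shown sit.

The compounds shown leave open whether any group on this saturated chain carbon bound to an amine nitrogen in a ring would yield a readable number in this assay.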